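Chloro to fluoro on the salicylanilide-type core, single substitution

The source may hold more compounds than are shown below. What is called first, only, known or untested is meant among the compounds shown, and "the series" means these compounds.

Of the compounds shown here, two carry a number so far. Compound 1 `O=C(Nc1ccc(C(F)(F)F)cc1)c1ccc(Cl)cc1O`, in a functional assay on Jurkat cells (Homo sapiens) for cytotoxicity, read by luminescence and CellTiter-Glo, with a stated time of 3 days (on this read-out lower numbers stand for stronger inhibition and higher numbers for weaker inhibition), gives 670 nM. Compound 2 `O=C(Nc1cc(C(F)(F)F)cc(C(F)(F)F)c1)c1cc(Br)c(-c2ccccc2)cc1O` in this assay gives 680 nM. Compound 1 holds the lower of the two numbers, but the gap to compound 2 lies within the usual scatter, so nothing can be read into which of the two stands where; the two values simply sit together.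

Compound 3 `O=C(Nc1ccc(C(F)(F)F)cc1)c1ccc(F)cc1O` has not yet been measured in this assay. It differs from compound 1 in one place: fluoro in place of chloro on an aromatic carbon, the exchange sitting meta to a hydroxy group and para to a large group on the shared core. Within the data shown here, no pair of measured compounds shows what such an exchange does, so the size of the step has to be guessed from the structures alone. Since one halogen is swapped for a smaller one at a single aromatic carbon, the expected change is small, at most a modest move toward a higher number, and possibly none beyond the scatter.

Taking the value of compound 1, 670 nM, as the anchor, the expected step is a 1.4-fold higher number from compound 1 to compound 3 (0.15 log units; within the scatter). Compound 3 is therefore estimated at 950 nM, with a plausible range from 400 nM to 2500 nM.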

Compound 3, half-maximal inhibitory concentration: 800 nM
Compound 3: the middle estimate sits 1.2-fold (0.07 log units) above what was measured; the measured number falls inside the stated range.
By their numbers in this assay, from the lowest: compounds 1, 2 and 3 (each within the scatter of the next).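

In this assay, among these compounds, the pair gives the first direct reading at this position, the aromatic carbon meta to a hydroxy group and para to a large group, and the step reads a 1.2-fold higher number from compound 1 to compound 3 (0.08 log units; within the scatter) with only the halogen exchanged. The read-out therefore does not separate chloro from fluoro here, so chloro is not required at this carbon for a number of this size on the shared core. No measurement on hand bears on why the two halogens read alike.

Going by these compounds, it remains open whether this carbon accepts groups of a different kind, such as an amine, a carboxylic acid or a longer alkoxy chain, or whether the number is kept only among halogens. A single pair also cannot show whether fluoro in place of chloro reads the same on a core carrying other substituents, such as the bis(trifluoromethyl) ring and the phenyl and bromo groups of compound 2.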